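Swapping the amide side chain: pyrrolidine to methylpiperidine

This account rests on a few compounds, and the source may have more. Where it says the series, first, only, none or still open, it means among the compounds named here.

Of the compounds shown here, three sharing one core have been tested in an ADME assay on cells (Hepatocyte, Rattus norvegicus) for metabolic stability; on this read-out higher numbers stand for fast clearance and lower numbers for slow clearance. Compound 1 `Cc1ccc2[nH]c(C(=O)N[C@H]3CCN(S(=O)(=O)N4CCCCC4)C[C@@H]3C(=O)NCCN(C)C)cc2c1` gives 25 uL/min. For the measured compounds named here, compound 2 `Cc1ccc2[nH]c(C(=O)N[C@H]3CCN(S(=O)(=O)N(C)C)C[C@@H]3C(=O)NCCN(C)C)cc2c1` gives 10 uL/min, and the only single-point step among the measured compounds, a 2.5-fold lower number from compound 1 to compound 2 (0.40 log units; beyond the scatter), came with dimethylamino in place of piperidin-1-yl on a sulfonyl sulfur. Compound 3 `Cc1ccc2[nH]c(C(=O)N[C@H]3CN(S(=O)(=O)c4ccccc4)C[C@@H]3C(=O)NC[C@H]3CCCN3)cc2c1` gives 10 uL/min; it sits level with compound 2 at the digits shown and, together with compound 2, at the lowest of the three numbers, while compound 1 stands higher. Compound 4 `Cc1ccc2[nH]c(C(=O)N[C@H]3CN(S(=O)(=O)c4ccccc4)C[C@@H]3C(=O)N[C@H]3CCCN(C)C3)cc2c1` differs from compound 3 only on an amide-type nitrogen whose other neighbour is a carbonyl carbon: 1-methylpiperidin-3-yl in place of (pyrrolidin-2-yl)methyl on an amide-type nitrogen. Going by the values given here, no measured step touches that position, so nothing bears on it directly; the one measured step changed a group on a sulfonyl sulfur instead, and was modest. For compound 4 the expected step is a 1.2-fold higher number from compound 3 to compound 4 (0.08 log units; within the scatter), that is, no move beyond the scatter. Compound 4 is therefore estimated at 12 uL/min in this assay, with a range of 6 uL/min to 25 uL/min.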

Compound 4, intrinsic clearance in a liver preparation (reported as CLH), per the amount of preparation that the assay uses: 23 uL/min
Compound 4: the middle estimate sits 1.9-fold (0.28 log units) below what was measured; the measured number falls inside the stated range.
By their numbers in this assay, from the lowest: compounds 2 and 3 (each within the scatter of the next); then compounds 4 and 1 (each within the scatter of the next).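

In this assay, for the compounds shown here, the amide side chain proves able to shift the number: the change to 1-methylpiperidin-3-yl brought a 2.3-fold higher number from compound 3 to compound 4 (0.36 log units; beyond the scatter), a modest step and the first reading at this position. This one swap changes several things at once, since a five-membered ring becomes a six-membered one, the count of hydrogen-bond donors goes from 1 to 0, and the group's shape changes too, so the step cannot be credited to any one of them. No measured evidence here explains the rise. Still open, from the compounds shown here alone, is which of these differences matters: a piperidin-3-yl group without the methyl would test the donor, and a 1-methylpyrrolidin-3-yl group would test the ring size. Going by these compounds, whether the same swap gives a similar step with a different group on the sulfonyl sulfur also remains unknown.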